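The source may hold more compounds than are shown below. What is called first, only, known or untested is meant among the compounds shown, and "the series" means these compounds.

Compound 1, `COc1ccc2[nH]c3c(c2c1)CCNC31CCN(Cc2ccccc2)CC1`, gives 12600 nM in an assay on FRT cells for positive allosteric modulation of Cystic fibrosis transmembrane conductance regulator variant N1303K (Homo sapiens), in the presence of a further agent that is not named here; on this read-out lower numbers stand for an effect already at smaller amounts and higher numbers for an effect only at larger amounts of compound.
Compound 2, `COc1ccc2[nH]c3c(c2c1)CCNC31CCN(Cc2ccc(F)c(Cl)c2F)CC1`, gives 4500 nM in this assay.
Compound 3, `COc1ccc2[nH]c3c(c2c1)CCNC31CCN(Cc2ccc(F)cc2F)CC1`, gives 2000 nM in this assay.

All three share one core and differ only in the ring carried on the saturated chain carbon bound to the amine nitrogen. Compound 3 has the lowest number of the three: the step of a 6.3-fold lower number from compound 1 to compound 3 (0.80 log units; beyond the scatter) and the step of a 2.3-fold lower number from compound 2 to compound 3 (0.35 log units; beyond the scatter) both lie beyond the scatter, so compound 3 is the most potent of the measured set. The remaining step, a 2.8-fold lower number from compound 1 to compound 2 (0.45 log units; beyond the scatter), shows that adding fluorines and a chloro to the plain ring also lowered the number, though less than adding fluorines alone.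

Compound 4, `COc1ccc2[nH]c3c(c2c1)CCNC31CCN(Cc2cc(F)ccc2F)CC1`, has not been measured. Its change from compound 3 is 2,5-difluorophenyl in place of 2,4-difluorophenyl on a saturated chain carbon bound to an amine nitrogen in a ring. Going by the values given here, none of the measured steps moves a fluorine from one ring position to another; they add halogens to a bare ring or remove a chloro. Among the compounds with values here, they show only that this ring is sensitive to its substituents, with every step beyond the scatter. On that indirect basis a change in this assay of modest size is expected for compound 4, more likely toward a higher number than toward a lower one, since compound 3 is already the best measured point, giving a 1.6-fold higher number from compound 3 to compound 4 (0.20 log units; within the scatter). The expected value for compound 4 is 3200 nM, within a range from 1100 nM to 9500 nM.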

Compound 4, half-maximal effective concentration: 11100 nM
Compound 4: middle estimate off by 3.5-fold (0.54 log units), on the low side; measured number above the stated range.
By their numbers in this assay, from the lowest: compound 3; then compound 2; then compounds 4 and 1 (each within the scatter of the next).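

In this assay, the arrangement of the fluorines on this ring matters, not only their presence: 2,5-difluorophenyl and 2,4-difluorophenyl contain the same atoms, yet exchanging one for the other gives a 5.6-fold higher number from compound 3 to compound 4 (0.74 log units; beyond the scatter). Carrying two fluorines therefore does not by itself secure a gain over the bare phenyl ring, since a 1.1-fold lower number from compound 1 to compound 4 (0.06 log units; within the scatter) stays within the scatter, while the more heavily substituted 3-chloro-2,4-difluorophenyl ring keeps an advantage, with a 2.5-fold higher number from compound 2 to compound 4 (0.39 log units; beyond the scatter). Nothing measured here explains why this small rearrangement has so large an effect.

The compounds shown leave open whether a single fluorine can account for the standing of compound 3, something that 4-fluorophenyl and 2-fluorophenyl on the same saturated chain carbon would help to separate. They also leave open whether the 2,4-difluorophenyl pattern works only with fluorine, or whether a ring carrying a nitrile or a trifluoromethyl group in place of one fluorine would give a similar number.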